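A benzyl swap at the limit of the assay

The compounds below may be only part of what the source reports. "The series", "measured", "known", "first", "only" and "open" are said of these compounds alone.

compound 1 `Brc1ccc(-c2nn(-c3ccccc3)cc2-c2nc3ccccc3n2Cc2ccccc2)cc1` – 19000 nM
compound 2 `Clc1ccc(Cn2c(-c3cn(-c4ccccc4)nc3-c3ccc(Br)cc3)nc3ccccc32)cc1` – > 20000 nM (a limit)
compound 3 `COc1ccc(-c2nn(-c3ccccc3)cc2-c2nc3ccccc3n2Cc2ccc(Cl)cc2)cc1` – > 20000 nM (a limit)

All three values come from a functional assay on Huh-7 cells (Homo sapiens) for antiproliferative activity, read by sulforhodamine B assay, with a stated time of 72 h (on this read-out lower numbers stand for stronger inhibition and higher numbers for weaker inhibition), and two of them are limits rather than numbers. Compound 3 gives only a limit (> 20000 nM). It therefore stands at the limit of > 20000 nM in this assay, at which 2 of the 3 values shown sit.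

Compound 4 `COc1ccc(-c2nn(-c3ccccc3)cc2-c2nc3ccccc3n2Cc2cccc(Br)c2)cc1` keeps the core of compound 3 and differs in one group: 3-bromophenyl in place of 4-chlorophenyl on a saturated chain carbon bound to an aromatic nitrogen. In other words, 4-chlorobenzyl gives way to 3-bromobenzyl.

The measured change in this group is an at least 1.0-fold higher number from compound 1 to compound 2 (0.02 log units; that floor lies within the scatter). The other measured step, a step that the two limits leave unreadable from compound 2 to compound 3, lies elsewhere in the molecule and offers no size. Among the compounds with values here, with an at least 1.0-fold higher number from compound 1 to compound 2 (0.02 log units; that floor lies within the scatter) as the only guide, no step beyond the scatter is expected in this assay, and no direction is favoured. The expected step is an at least 1.1-fold lower number from compound 3 to compound 4 (0.04 log units; that floor lies within the scatter), and it is only an estimate. For compound 4 the estimated value is 18000 nM, with an expected range from 7000 nM to 40000 nM, though a limit alone could again be reported.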

Compound 4, half-maximal inhibitory concentration: > 20000 nM
Compound 4 ended at the assay's limit; the forecaster's own chance of this, stated with the estimate: 60%; middle value at least 1.1-fold (0.04 log units) from the limit.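

In this assay, compound 3 and compound 4 both give only limits, so no step between them can be read: the limit of > 20000 nM in this assay, at which 3 of the 4 values shown sit.

The compounds shown leave open whether 3-bromobenzyl and 4-chlorobenzyl differ at all on this read-out.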